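Chloro added between ring nitrogens of a purine-like core

The source may hold more compounds than are shown below. What is called first, only, known or untested is meant among the compounds shown, and "the series" means these compounds.

Among the compounds with values here, compound 1 `ClCc1ccc(Cn2cnc3c(Cl)ncnc32)cc1` gives 7760 nM in a functional assay on NCI-H23 cells (Homo sapiens) for cytotoxicity, read by sulforhodamine B assay, with a stated time of 48 h (a higher number here means that more compound is tolerated, a lower number that less compound is tolerated), the lowest of the two numbers measured; compound 2 `ClCc1cccc(Cn2cnc3c(Cl)nc(Cl)nc32)c1` gives 22400 nM in this assay and differs from compound 1 in two places, so no single step connects them. Compound 3 `ClCc1ccc(Cn2cnc3c(Cl)nc(Cl)nc32)cc1` differs from compound 1 by chloro in place of hydrogen on an aromatic carbon. With no measured step of this kind in the series, a modest rise in the number is expected, not far beyond the scatter, a 1.7-fold higher number from compound 1 to compound 3 (0.22 log units; within the scatter). Compound 3 is therefore estimated at 13000 nM, with a range from 5000 nM to 35000 nM.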

Compound 3, concentration lethal to 50% of the cells: 58900 nM
The estimate for compound 3 lay 4.5-fold (0.66 log units) below the measured number; measured number outside the range, above it.
By their numbers in this assay, from the lowest: compound 1; then compound 2; then compound 3.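

Within the data shown here, the step of a 7.6-fold higher number from compound 1 to compound 3 (0.88 log units; beyond the scatter) in this assay is the first single-place comparison. It shows that the added chloro group, between two ring nitrogen atoms, moves the number beyond the scatter, towards more compound being tolerated. No measurement at hand accounts for this shift.

Among the compounds shown, only hydrogen and chloro occupy this position, so the effect of an amine or a methoxy group there remains open. On these data alone, whether the step holds when the chloromethyl group is replaced by a hydroxymethyl group also remains open.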